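The source may report more compounds than this note shows. Statements on the series, on what has been measured and on what is new or still open speak of the compounds shown alone.

Measured compounds:
- compound 1 `Cc1ccc(S(=O)(=O)NCc2cn(C[C@H](O)[C@H]3OC(=O)C(OCc4ccccc4)=C3OCc3ccccc3)nn2)cc1`, 14400 nM
- compound 2 `O=C1O[C@H]([C@@H](O)Cn2cc(-c3cc(F)cc(F)c3)nn2)C(OCc2ccccc2)=C1OCc1ccccc1`, 40800 nM
- compound 3 `Cc1ccc(-c2cn(C[C@H](O)[C@H]3OC(=O)C(OCc4ccccc4)=C3OCc3ccccc3)nn2)cc1`, 25500 nM

In a functional assay on HeLa cells (Homo sapiens) for antiproliferative activity, read by MTT assay, with a stated time of 72 h (on this read-out lower numbers stand for stronger inhibition and higher numbers for weaker inhibition), compound 3 stands second highest of the three numbers: its nearest neighbour is compound 2, a 1.6-fold lower number from compound 2 to compound 3 (0.20 log units; within the scatter), and its furthest is compound 1, a 1.8-fold higher number from compound 1 to compound 3 (0.25 log units; within the scatter), both within the scatter. For the measured compounds named here, the one step beyond the scatter is a 2.8-fold higher number from compound 1 to compound 2 (0.45 log units; beyond the scatter), modest in size.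

Compound 4 `CCCCc1cn(C[C@H](O)[C@H]2OC(=O)C(OCc3ccccc3)=C2OCc2ccccc2)nn1` differs from compound 3 by butyl in place of 4-methylphenyl on an aromatic carbon. Going by the values given here, no measured step swaps an aromatic group for a chain; the two steps that land on compound 3 both stay within the scatter, and the shared core is unchanged. The expectation for this assay is therefore no step beyond the scatter, written as a 1.2-fold higher number from compound 3 to compound 4 (0.07 log units; within the scatter).

Compound 4 is estimated at 30000 nM, with a range from 12000 nM to 75000 nM.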

Compound 4, half-maximal inhibitory concentration: 18100 nM
Compound 4: the middle estimate sits 1.7-fold (0.22 log units) above what was measured; measured number inside the range.
By their numbers in this assay, from the lowest: compounds 1, 4, 3 and 2 (each within the scatter of the next, the first and the last beyond it).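

In this assay, compound 4 shows that this position tolerates an open butyl chain with no ring in place of the aromatic 4-methylphenyl (a 1.4-fold lower number from compound 3 to compound 4 (0.15 log units; within the scatter)). Its number also stays within the scatter of the sulfonyl-bearing compound (a 1.3-fold higher number from compound 1 to compound 4 (0.10 log units; within the scatter)). For the compounds shown here, only the step from the 3,5-difluorophenyl group passes the scatter, and modestly (a 2.3-fold lower number from compound 2 to compound 4 (0.35 log units; beyond the scatter)).

As far as these compounds go, whether a longer chain, a hydroxyl-bearing chain or an amine at this position would move the number stays open. Nothing available here explains these small differences.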